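The source may hold more compounds than are shown below. What is called first, only, known or untested is meant among the compounds shown, and "the series" means these compounds.

The three measured compounds share one core and differ in the group on an aromatic carbon of that core. Compound 1 `CCCCNC(=O)c1cc(C)c2nc(CCC)n(Cc3ccc(-c4ccccc4C(=O)O)cc3)c2c1` gives 164 nM in an assay on isolated protein for displacement of a labelled ligand from Type-2 angiotensin II receptor (Homo sapiens), with a stated time of 180 min; a lower number here means a stronger inhibitor, a higher number a weaker inhibitor. Compound 2 `CCCc1nc2c(C)cc(C(=O)Nc3ccc(C)cc3)cc2n1Cc1ccc(-c2ccccc2C(=O)O)cc1` gives 61 nM in this assay, and compound 3 `CCCC(=O)Nc1cc(C)c2nc(CCC)n(Cc3ccc(-c4ccccc4C(=O)O)cc3)c2c1` gives 53 nM in this assay. Compound 3 has the lowest of the three numbers, but its gap to compound 2, a 1.2-fold lower number from compound 2 to compound 3 (0.06 log units; within the scatter), lies within the scatter, so these two cannot be ordered; against compound 1 the steps of a 3.1-fold lower number from compound 1 to compound 3 (0.49 log units; beyond the scatter) and a 2.7-fold lower number from compound 1 to compound 2 (0.43 log units; beyond the scatter) are both modest and beyond the scatter.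

Compound 4 `CCCc1nc2c(C)cc(NC(=O)c3ccc(C)cc3)cc2n1Cc1ccc(-c2ccccc2C(=O)O)cc1` differs from compound 3 by 4-methylphenyl in place of propyl on a carbonyl carbon. Among the compounds with values here, the one measured step that bears on this change is a 2.7-fold lower number from compound 1 to compound 2 (0.43 log units; beyond the scatter), where a 4-methylphenyl likewise replaced a chain, there on an amide-type nitrogen. Within the data shown here, because the step of a 2.7-fold lower number from compound 1 to compound 2 (0.43 log units; beyond the scatter) was modest, a modest lowering of the number in this assay is expected for compound 4 too, though with less certainty, since no measured pair places the 4-methylphenyl on a carbonyl carbon. Compound 4 is therefore expected to give 30 nM in this assay, within 12 nM to 80 nM. The expected step is a 1.8-fold lower number from compound 3 to compound 4 (0.25 log units; within the scatter).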

Compound 4, half-maximal inhibitory concentration: > 10000 nM
Compound 4: a limit, no number; the forecaster's own chance of this, stated with the estimate: 2%; at least 330-fold (2.52 log units) between middle value and limit.
By their numbers in this assay, from the lowest: compounds 3 and 2 (each within the scatter of the next); then compound 1. At a limit, above all of these: compound 4.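

Compound 4 stands at a limit of the assay and not at a number: the limit of > 10000 nM in this assay, at which 1 of the 4 values shown sits. Within the data shown here, with 4-methylphenyl in place of propyl on a carbonyl carbon, the step is an at least 180-fold higher number from compound 3 to compound 4 (2.27 log units; beyond the scatter), so at this position a ring on the carbonyl carbon is not interchangeable with a propyl chain, a contrast the earlier compounds gave no sign of. Keeping the 4-methylphenyl and reversing only the amide linkage gives an at least 160-fold higher number from compound 2 to compound 4 (2.21 log units; beyond the scatter), and the comparison with the butylcarbamoyl group gives an at least 60-fold higher number from compound 1 to compound 4 (1.78 log units; beyond the scatter), so the direction of the amide matters when this ring is carried.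

The compounds shown leave open whether a longer chain, such as butyl or pentyl, on this carbonyl carbon would behave like propyl. They also leave open whether an unsubstituted phenyl or a benzyl group would behave like 4-methylphenyl.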